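The compounds below may be only part of what the source reports. "The series", "measured", "known", "first", "only" and "open" are said of these compounds alone.

Compound 1, `COc1cc(/C=C/C(=O)c2cccc(NC(=O)c3ccc(Cl)c(Cl)c3)c2)ccc1O`: 2.97 ug/mL
Compound 2, `COc1cc(/C=C/C(=O)c2cccc(N)c2)ccc1O`: 2.87 ug/mL
Compound 3, `COc1cc(/C=C/C(=O)c2cccc(NC(=O)c3ccccc3)c2)ccc1O`: 0.37 ug/mL

All three were tested in a functional assay on HUVEC cells (Homo sapiens) for inhibition; on this read-out higher numbers stand for weaker inhibition and lower numbers for stronger inhibition. Compound 1 gives the highest number of the three, but only just: the step of a 1.0-fold lower number from compound 1 to compound 2 (0.01 log units; within the scatter) lies within the scatter, so compounds 1 and 2 cannot be told apart, whereas the step of an 8.0-fold lower number from compound 1 to compound 3 (0.90 log units; beyond the scatter) lies beyond it. The step of a 7.8-fold lower number from compound 2 to compound 3 (0.89 log units; beyond the scatter) shows the same gap from the other side.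

Compound 4, `COc1cc(/C=C/C(=O)c2cccc(NC(=O)c3cc(Cl)cc(Cl)c3)c2)ccc1O`, is the not yet measured compound. It differs from compound 1 in one place: 3,5-dichlorophenyl in place of 3,4-dichlorophenyl on a carbonyl carbon. Both chlorines stay on the ring; only one of them moves. The measured steps touch this change only at a distance. The step from compound 1 to compound 3 shows that taking both chlorines away gives a modest move to stronger inhibition; the step from compound 1 to compound 2 shows that removing the whole group changes nothing beyond the scatter. Within the data shown here, no measured pair shows what moving a single chlorine does. The most cautious expectation is therefore a number close to that of compound 1, with some chance of landing nearer compound 3. Compound 4 is estimated at 2 ug/mL in this assay, within 0.6 ug/mL to 6 ug/mL, which means an expected step of a 1.5-fold lower number from compound 1 to compound 4 (0.17 log units; within the scatter).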

Compound 4, half-maximal inhibitory concentration: 0.75 ug/mL
Compound 4: middle estimate off by 2.7-fold (0.43 log units), on the high side; measured number inside the range.
By their numbers in this assay, from the lowest: compound 3; then compound 4; then compounds 2 and 1 (each within the scatter of the next).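

In this assay moving a single chlorine gives a 4.0-fold lower number from compound 1 to compound 4 (0.60 log units; beyond the scatter) and so the place of the chlorines on the ring matters, not only their presence. The (3,5-dichlorophenyl)carbonyl group also gives a 3.8-fold lower number from compound 2 to compound 4 (0.58 log units; beyond the scatter) when it replaces the hydrogen on the nitrogen, whereas the (3,4-dichlorophenyl)carbonyl group made no difference beyond the scatter at that same place. The chlorines still bring no gain over the bare ring, since a 2.0-fold higher number from compound 3 to compound 4 (0.31 log units; beyond the scatter) leaves the unsubstituted phenyl with the lower number.

On these data alone, whether methyl, methoxy or an amine in the places of the chlorines would follow compound 3 or compound 4 remains open, as does the effect of a single chlorine on the ring. Nothing measured here explains why the arrangement of the chlorines changes the number.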